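Octyl to hydroxypropyl on a triazole side chain

A few compounds are considered here, and "the series" means these few. Any claim that something is new, unique, unknown or untested is made for them only; others in the source may bear on it.

Measured compounds:
compound 1 `COc1nc2ccc(Br)cc2cc1C(c1ccccc1)n1cc(-c2ccc(Br)cc2)nn1`: 6.28%
compound 2 `CCCCCCc1cn(C(c2ccccc2)c2cc3cc(Br)ccc3nc2OC)nn1`: -3.17%
compound 3 `CCCCCCCCc1cn(C(c2ccccc2)c2cc3cc(Br)ccc3nc2OC)nn1`: 14.6%

In an ADME assay on HEK293 cells (Homo sapiens) for cytotoxicity, read by sulforhodamine B assay, with a stated time of 48 h, tested at 10 uM (on this read-out higher numbers stand for more inhibition at the one concentration tested (going by the name of the read-out) and lower numbers for less inhibition), compound 3 gives the largest of the three numbers, though its gap to compound 1, a number 8.3 percentage points higher from compound 1 to compound 3 (within the scatter), is within the scatter; only the gap to compound 2, a number 17.8 percentage points higher from compound 2 to compound 3 (beyond the scatter), lies beyond it. Compound 4 `COc1nc2ccc(Br)cc2cc1C(c1ccccc1)n1cc(CCCO)nn1` differs from compound 3 by hydroxy in place of pentyl on a saturated chain carbon, three bonds along the chain from an aromatic carbon. Among the measured compounds shown here, the one step that bears on this change is the chain shortening between compound 2 and compound 3, where lengthening the chain raised the number; compound 4 shortens it further and adds a hydroxy. A modest drop is therefore expected in this assay, about a number 14.6 percentage points lower from compound 3 to compound 4 (beyond the scatter). Compound 4 is estimated at 0%, between -12% and 12%.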

Compound 4, a percentage reported as inhibition, at one concentration (the size of the read-out at that concentration, not a potency): 27.4%
The estimate for compound 4 lay 27.4 percentage points below the measured number; the whole stated range lies below it.
By their numbers in this assay, from the lowest: compounds 2, 1 and 3 (each within the scatter of the next, the first and the last beyond it); then compound 4.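

In this assay, replacing the octyl chain with the shorter 3-hydroxypropyl chain raises the number rather than lowering it (a number 12.8 percentage points higher from compound 3 to compound 4 (beyond the scatter)), and the rise over the hexyl compound is larger (a number 30.6 percentage points higher from compound 2 to compound 4 (beyond the scatter)). The same 3-hydroxypropyl chain also stands above the 4-bromophenyl group at this position (a number 21.1 percentage points higher from compound 1 to compound 4 (beyond the scatter)), so chain length alone does not order these compounds. No measurement offered here accounts for this rise. As far as these compounds go, whether the hydroxy or the shorter chain drives it remains open. A plain propyl chain, or an amine in place of the hydroxy, would help separate the two.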